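A few compounds are considered here, and "the series" means these few. Any claim that something is new, unique, unknown or untested is made for them only; others in the source may bear on it.

Among the compounds with values here, in a functional assay on MCF7 cells (Homo sapiens) for antiproliferative activity, read by sulforhodamine B assay, with a stated time of 3 days (on this read-out lower numbers stand for stronger inhibition and higher numbers for weaker inhibition), three compounds have numbers so far. Compound 1 `O=c1ccn(C2COc3ccccc3CO2)c(=O)[nH]1` gives 5000 nM, compound 2 `c1ccc(Sc2ncnc3[nH]cnc23)cc1` gives 31000 nM, and compound 3 `C=CCOc1ncnc2ncn(C3COc4ccccc4CO3)c12` gives 20900 nM. Compound 3 stands level with compound 2 within the usual scatter, while its number lies higher than that of compound 1 by more than the scatter. Compound 4 `CSc1ncnc2ncn(C3COc4ccccc4CO3)c12` has not yet been measured. It differs from compound 3 in one place, with methylsulfanyl in place of allyloxy on an aromatic carbon. Within the data shown here, no two measured compounds differ in only one place, so the data offer no direct guide to this exchange. The expectation therefore starts from compound 3 at 20900 nM, and no change beyond the scatter is expected, with only a slight lean toward a lower number. The estimated step is a 1.4-fold lower number from compound 3 to compound 4 (0.14 log units; within the scatter). For compound 4 the estimated value is 15000 nM, with an expected range from 6000 nM to 35000 nM.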

Compound 4, half-maximal inhibitory concentration: 31800 nM
Compound 4: middle estimate off by 2.1-fold (0.33 log units), on the low side; measured number inside the range.
By their numbers in this assay, from the lowest: compound 1; then compounds 3, 2 and 4 (each within the scatter of the next).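

In this assay, putting methylsulfanyl in place of allyloxy on this aromatic carbon gives a 1.5-fold higher number from compound 3 to compound 4 (0.18 log units; within the scatter), so compound 3 and compound 4 stand level. Within the data shown here, this is the first direct comparison at this position, and it shows that the exchange of the allyloxy chain, with its oxygen and its double bond, for the smaller methylsulfanyl group, with its sulfur, shifts the number by no more than the scatter. Nothing shown gives a reason for this outcome.

Both groups are uncharged and carry no ring and no hydrogen-bond donor, so this single pair speaks only for groups of that kind. On these data alone, what an amine, a phenyl ring or a longer chain on this carbon would give remains open, as does whether any group here could move the number beyond the scatter.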